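Chain length in the cyanoguanidine series: compound 3 to compound 4

The source may hold more compounds than are shown below. What is called first, only, known or untested is meant among the compounds shown, and "the series" means these compounds.

Within the data shown here, in a functional assay on HONE1 cells for cytotoxicity against HONE1 cell line (Homo sapiens) (a higher number here means a weaker inhibitor, a lower number a stronger inhibitor), three members have numbers so far. Compound 1 `CC1C(=O)N(CCCCCCCOc2ccc(Cl)cc2)/C(=N\C#N)N1c1ccncc1` gives 371 nM. Compound 2 `CCC1C(=O)N(CCCCCCOc2ccc(Cl)cc2)/C(=N\C#N)N1c1ccncc1` gives 3870 nM. Compound 3 `N#C/N=C1\N(CCCCCOc2ccc(Cl)cc2)C(=O)CCN1c1ccncc1` gives 3450 nM. Compound 3 stands second highest of the three; its number and that of compound 2 lie within the usual scatter of each other, so no order between those two can be read, while compound 1 sits well below compound 3, beyond the scatter. Compound 1 differs from compound 3 in two places at once, in the chain and in the substituent on the shared core, so no single-step comparison can be drawn from the numbers shown.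

Compound 4 `N#C/N=C1\N(CCCCCCCOc2ccc(Cl)cc2)C(=O)CCN1c1ccncc1` has not yet been measured in this assay. It differs from compound 3 in one place: 2-(4-chlorophenoxy)ethyl in place of 4-chlorophenoxy on a saturated chain carbon, five bonds along the chain from an amide-type nitrogen in a ring. This lengthens the chain to that of compound 1 while keeping the unsubstituted core of compound 3. Since compound 1 with the longer chain gives 371 nM, a step toward a lower number is expected for compound 4, of moderate size, a 3.8-fold lower number from compound 3 to compound 4 (0.58 log units; beyond the scatter), though the unknown share of the core substituent in that difference leaves the size uncertain. Compound 4 is therefore estimated at 900 nM, with a range from 280 nM to 3000 nM.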

Compound 4, half-maximal inhibitory concentration: 3440 nM
The estimate for compound 4 lay 3.8-fold (0.58 log units) below the measured number; measured number above the stated range.
By their numbers in this assay, from the lowest: compound 1; then compounds 4, 3 and 2 (each within the scatter of the next).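

In this assay, 2-(4-chlorophenoxy)ethyl in place of 4-chlorophenoxy on a saturated chain carbon, five bonds along the chain from an amide-type nitrogen in a ring, gives a 1.0-fold lower number from compound 3 to compound 4 (0.00 log units; within the scatter), so on this core the longer chain leaves the number unchanged within the scatter. Compound 4 shares its chain with compound 1 and differs from it in the core, yet compound 4 gives 3440 nM and compound 1 gives 371 nM, which shows that this chain alone does not bring the lower number of compound 1 onto the core of compound 3. No measurement shown here offers an explanation for the flat step.

Still open is whether the same lengthening has any effect on the core of compound 1, since no pair shown varies the chain alone on that core. Also open, going by these compounds, is whether a longer chain than that of compound 4, or an amine or a carboxylic acid in place of 4-chlorophenoxy at this saturated chain carbon, would shift the number on the core of compound 3.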